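A few compounds are considered here, and "the series" means these few. Any claim that something is new, unique, unknown or untested is made for them only; others in the source may bear on it.

Measured compounds:
Compound 1 `CC[C@H](C)[C@H](N)CN(C(=O)[C@@H]1C[C@H]1c1ccccc1)c1ccc(-c2ccccc2)cc1` — 230 nM; 800 nM (2 entries) in a functional assay for agonist activity at G protein-coupled receptor 88 (Homo sapiens), read by HTRF and cAMP accumulation; on this read-out higher numbers stand for an effect only at larger amounts of compound and lower numbers for an effect already at smaller amounts
Compound 2 `CC(C)CCCN(C(=O)[C@@H]1C[C@H]1c1ccccc1)c1ccc(-c2ccccc2)cc1` — > 100 nM in this assay
Compound 3 `CC(C)[C@H](N)CN(C(=O)[C@@H]1C[C@H]1c1ccccc1)c1ccc(-c2ccccc2)cc1` — 1.1 nM in this assay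

Compound 2 stands at the limit of this assay: its value of > 100 nM is a limit and not a number. Compound 4 `CCC(C)CNCCN(C(=O)[C@@H]1C[C@H]1c1ccccc1)c1ccc(-c2ccccc2)cc1` differs from compound 2 by (2-methylbutyl)amino in place of isobutyl on a saturated chain carbon, two bonds along the chain from an amide-type nitrogen. Within the data shown here, the one measured step from compound 2, an at least 90-fold lower number from compound 2 to compound 3 (1.95 log units; beyond the scatter), bears on this change, as there too a nitrogen enters the chain. Compound 1, which also carries a chain nitrogen, gives 230 nM; 800 nM (2 entries). Compound 4 is therefore expected to improve on compound 2 in this assay by a step that the limit leaves unreadable from compound 2 to compound 4, though by less than compound 3. The estimate for compound 4 is 200 nM, ranging from 30 nM to 1500 nM.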

Compound 4, half-maximal effective concentration: 4.7 nM
Compound 4: the middle estimate sits 43-fold (1.63 log units) above what was measured, and the stated range ends above it.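

Compound 2 gives > 100 nM in this assay, which is a limit and not a number. A nitrogen set further out along the chain, as (2-methylbutyl)amino, still brings an at least 21-fold lower number from compound 2 to compound 4 (1.32 log units; beyond the scatter). Putting ((2-methylbutyl)amino)methyl in place of 1-amino-2-methylpropyl gives only a 4.3-fold higher number from compound 3 to compound 4 (0.63 log units; beyond the scatter), so a low number here is not tied to a single placement of the chain nitrogen.

Going by these compounds, the true size of the step from compound 2 stays open: the limit of > 100 nM in this assay, at which 1 of the 4 values shown sits. Also open is whether an ether oxygen in place of the chain nitrogen, or a longer chain on that nitrogen, would hold the number this low.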